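The source may report more compounds than this note shows. Statements on the series, on what has been measured and on what is new or still open speak of the compounds shown alone.

Among the compounds with values here, compound 2 `COC(=O)Nc1cc(-c2ccc(OC[C@@](C)(N)CC(C)C)nc2)ccn1` has the higher of the two numbers measured so far in an assay on brain (strain C57BL6) for displacement of a labelled ligand from AP2-associated protein kinase 1 (Mus musculus), read by scintillation counting, with a stated time of 1 h (a higher number here means a weaker inhibitor, a lower number a stronger inhibitor), where compound 2 gives 4.9 nM. Within the data shown here, its nearest neighbour, compound 1 `COC(=O)Nc1cc(-c2cnc(OC[C@@](C)(N)CC(C)C)c(Cl)c2)ccn1`, gives 0.11 nM, and the only step on record, a 45-fold higher number from compound 1 to compound 2 (1.65 log units; beyond the scatter), concerns a hydrogen in place of chloro on an aromatic carbon. Compound 3 `COC(=O)Nc1cc(-c2cnc(OC[C@@](C)(N)CC(C)C)cc2C)ccn1` differs from compound 2 by methyl in place of hydrogen on an aromatic carbon, a change at a different place on the same ring, so that step bears on it only loosely. Compound 3 is expected to show a moderate gain, a 3.3-fold lower number from compound 2 to compound 3 (0.51 log units; beyond the scatter), with an estimate of 1.5 nM and a range from 0.25 nM to 10 nM.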

Compound 3, inhibition constant: 41 nM
The estimate for compound 3 lay 27-fold (1.44 log units) below the measured number; measured number above the stated range.
By their numbers in this assay, from the lowest: compound 1; then compound 2; then compound 3.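

In this assay, the aromatic carbon ortho to a large group and opposite the ring nitrogen does not tolerate this change well: methyl in place of hydrogen gives an 8.4-fold higher number from compound 2 to compound 3 (0.92 log units; beyond the scatter). The earlier step, a 45-fold higher number from compound 1 to compound 2 (1.65 log units; beyond the scatter), concerned chloro at a different place on the ring, so the two steps give no single rule for that ring. Nothing available explains the loss at this position.

Going by these compounds, it remains open whether the loss is specific to methyl, or whether a fluorine atom or a methoxy group on this carbon would give a similar number.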